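Moving the fluorine to another place on the ring

This account rests on a few compounds, and the source may have more. Where it says the series, first, only, none or still open, it means among the compounds named here.

For the measured compounds named here, compound 2 `Cn1cc(/C=C/C(=O)c2ccccc2F)cc1/C=C/C(=O)NO` gives 3400 nM in an assay on isolated protein for inhibition of histone deacetylase HD1B (Zea mays) (a lower number here means a stronger inhibitor, a higher number a weaker inhibitor), the higher of the two numbers known. Compound 1 `Cn1cc(/C=C/C(=O)c2ccccc2Cl)cc1/C=C/C(=O)NO` gives 1600 nM, and the step of a 2.1-fold higher number from compound 1 to compound 2 (0.33 log units; beyond the scatter) is the only one measured. Compound 3 `Cn1cc(/C=C/C(=O)c2ccc(F)cc2)cc1/C=C/C(=O)NO` differs from compound 2 by 4-fluorophenyl in place of 2-fluorophenyl on a carbonyl carbon. Going by the values given here, no measured step concerns where the fluorine sits on the ring; the one known step swaps the halogen itself, not its place, so it offers no guide. For compound 3 the expected step is a 1.1-fold lower number from compound 2 to compound 3 (0.05 log units; within the scatter), none beyond the scatter. Compound 3 is therefore estimated at 3000 nM, with a range from 1200 nM to 8000 nM.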

Compound 3, half-maximal inhibitory concentration: 24900 nM
Compound 3: middle estimate off by 8.3-fold (0.92 log units), on the low side; the whole stated range lies below it.
By their numbers in this assay, from the lowest: compound 1; then compound 2; then compound 3.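

In this assay the place of the fluorine proves to matter, and more than the identity of the halogen did: 4-fluorophenyl in place of 2-fluorophenyl gives a 7.3-fold higher number from compound 2 to compound 3 (0.86 log units; beyond the scatter), a larger step than the one between the two halogens. Set against the chlorine compound, 4-fluorophenyl in place of 2-chlorophenyl gives a 16-fold higher number from compound 1 to compound 3 (1.19 log units; beyond the scatter), the only large step so far. Nothing available accounts for this loss.

Still open, as far as these compounds go, is whether a bare phenyl would sit nearer compound 2 or compound 3. Also open, from the compounds shown here alone, is how a methoxy group or an amine on the ring would compare with the halogens.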